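From a Silicon-Bearing Group to Azido on the Shared Core

A few compounds are considered here, and "the series" means these few. Any claim that something is new, unique, unknown or untested is made for them only; others in the source may bear on it.

In a functional assay on SW480 cells (Homo sapiens) for antiproliferative activity, read by MTT assay, with a stated time of 48 h (on this read-out higher numbers stand for weaker inhibition and lower numbers for stronger inhibition), compound 3 `CC(C)=CCC[C@]1(C)/C=C/[C@@H](OC(=O)C=C(C)C)[C@](C)(O)/C=C/C(=O)/C(C[Si](C)(C)C(C)(C)C)=C\C1` gives 3350 nM, and compound 2 `CC[Si](CC)(CC)C/C1=C/C[C@](C)(CCC=C(C)C)/C=C/[C@@H](OC(=O)C=C(C)C)[C@](C)(O)/C=C/C1=O` gives 2690 nM. These two values lie within the scatter of each other, and both groups contain silicon. Compound 1 `CC(C)=CCC[C@]1(C)/C=C/[C@@H](OC(=O)C=C(C)C)[C@](C)(O)/C=C/C(=O)/C(CN2CCN(C)CC2)=C\C1`, whose group at the same place holds a six-membered non-aromatic ring, gives 800 nM, a lower number than either. The next structure, compound 4 `CC(C)=CCC[C@]1(C)/C=C/[C@@H](OC(=O)C=C(C)C)[C@](C)(O)/C=C/C(=O)/C(CN=[N+]=[N-])=C\C1`, keeps the shared core and alters one group: a group of 3 heavy atoms (3 nitrogen; no ring) in place of a group of 7 heavy atoms (6 carbon, 1 silicon; no ring), on a saturated chain carbon bound to a double-bonded ring carbon. The change lies on a saturated chain carbon bound to a double-bonded ring carbon.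

For the measured compounds named here, three measured steps bear on this place. The exchange between the two silicon-bearing groups gave a 1.2-fold higher number from compound 2 to compound 3 (0.10 log units; within the scatter). Leaving the ring-bearing group for a silicon-bearing one gave a 3.4-fold higher number from compound 1 to compound 2 (0.53 log units; beyond the scatter) and a 4.2-fold higher number from compound 1 to compound 3 (0.62 log units; beyond the scatter), both modest. Azido itself has not been measured here, so the data offer no direct precedent. Since the largest change at this place is only a 4.2-fold higher number from compound 1 to compound 3 (0.62 log units; beyond the scatter), a small step toward a lower number is expected, with no change beyond the scatter also possible. The estimated step is a 1.9-fold lower number from compound 3 to compound 4 (0.27 log units; within the scatter). Compound 4 is expected at 1800 nM, within an estimated range of 700 nM to 4500 nM.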

Compound 4, half-maximal inhibitory concentration: 4230 nM
The estimate for compound 4 lay 2.4-fold (0.37 log units) below the measured number, within the range that was stated.
By their numbers in this assay, from the lowest: compound 1; then compounds 2, 3 and 4 (each within the scatter of the next).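

In this assay, azido at this place, on a saturated chain carbon bound to a double-bonded ring carbon, does not separate from either silicon-bearing group: a 1.3-fold higher number from compound 3 to compound 4 (0.10 log units; within the scatter) and a 1.6-fold higher number from compound 2 to compound 4 (0.20 log units; within the scatter) are the steps read here, so silicon is not required for values in this band, and a group of 3 heavy atoms sits with groups of 7. Only 4-methylpiperazin-1-yl stands apart, with a 5.3-fold higher number from compound 1 to compound 4 (0.72 log units; beyond the scatter) adding to the two earlier steps from compound 1, and since that group also counts 7 heavy atoms, heavy-atom count does not follow the values across compounds 1 to 4. Nothing measured on these compounds accounts for this grouping.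

The compounds shown leave open which feature of 4-methylpiperazin-1-yl goes with the lower number of compound 1, and whether a morpholin-4-yl group, a piperidin-1-yl group or a simple primary amine at this place would sit with compound 1 or with compounds 2, 3 and 4. They also leave open whether the same grouping would hold on any cell line other than the one in this assay, since all four values come from that single read-out.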